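From ethynyl to iodo on the shared core

The source may report more compounds than this note shows. Statements on the series, on what has been measured and on what is new or still open speak of the compounds shown alone.

In a functional assay on K562 cells (Homo sapiens), read by MTT assay, with a stated time of 72 h (a lower number here means a stronger inhibitor, a higher number a weaker inhibitor), compound 1 `Cc1ncnc2c1c(-c1cccs1)cn2[C@@H]1O[C@H](CO)[C@@H](O)[C@H]1O` gives > 20000 nM, which is a limit of the assay and not a number. Compound 2 `Cc1ncnc2c1c(-c1cc3ccccc3o1)cn2[C@@H]1O[C@H](CO)[C@@H](O)[C@H]1O` gives 19500 nM. Compound 3 `C#Cc1cn([C@@H]2O[C@H](CO)[C@@H](O)[C@H]2O)c2ncnc(C)c12` gives 6920 nM, the lowest of the two actual numbers in the series, and compound 2 is its nearest neighbour.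

Compound 4 `Cc1ncnc2c1c(I)cn2[C@@H]1O[C@H](CO)[C@@H](O)[C@H]1O` carries iodo in place of ethynyl on an aromatic carbon, the carbon that holds the varied group throughout the series: iodo in place of ethynyl on an aromatic carbon.

For the measured compounds named here, three measured steps bear on this change, all at that carbon. Two show modest gains on moving from a ring substituent to ethynyl: a 2.8-fold lower number from compound 2 to compound 3 (0.45 log units; beyond the scatter) and an at least 2.8-fold lower number from compound 1 to compound 3 (0.46 log units; beyond the scatter). The third, an at least 1.0-fold lower number from compound 1 to compound 2 (0.01 log units; that floor lies within the scatter), has a floor within the scatter. Going by the values given here, no measured step involves iodo directly. Like ethynyl, iodo brings no ring, so compound 4 is expected to sit close to compound 3 at 6920 nM rather than return towards the ring-bearing compounds. The expected change, a 1.2-fold lower number from compound 3 to compound 4 (0.06 log units; within the scatter), is estimated to stay within the scatter, with no firm direction. The expected value for compound 4 is 6000 nM. The estimated range for compound 4 runs from 1500 nM to 20000 nM.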

Compound 4, half-maximal inhibitory concentration: 17800 nM
Estimate against measurement, compound 4: 3.0-fold (0.47 log units) below; the measured number falls inside the stated range.
By their numbers in this assay, from the lowest: compound 3; then compounds 4 and 2 (each within the scatter of the next). At a limit, above all of these: compound 1.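

In this assay, the absence of a ring at this carbon is not enough to hold the lower number, as the step to iodo shows: a 2.6-fold higher number from compound 3 to compound 4 (0.41 log units; beyond the scatter). Iodo also brings no ring, yet it gives no separation from the ring-bearing benzofuran compound: a 1.1-fold lower number from compound 2 to compound 4 (0.04 log units; within the scatter). Against compound 1 there is only a floor, an at least 1.1-fold lower number from compound 1 to compound 4 (0.05 log units; that floor lies within the scatter), and the reading of compound 1 is a limit of the assay and not a number: the limit of > 20000 nM in this assay, at which 1 of the 4 values shown sits.

Among the groups shown, ethynyl, the only one with a triple bond outside aromatic rings, is thus the one that stands apart, and compound 4 goes against any reading of the series as ring against no ring. Open, from the compounds shown here alone, is whether a longer chain ending in a triple bond would stay at the level of compound 3, and whether a methyl group, an amine or a carboxylic acid at this carbon would fall with compound 3 or with compounds 2 and 4.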